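The source may hold more compounds than are shown below. What is called first, only, known or untested is meant among the compounds shown, and "the series" means these compounds.

Two members of the series carry numbers in a functional assay on HCT-116 cells (Homo sapiens) for inhibition, read by MTT assay, with a stated time of 24 h, tested at 10 uM; a higher number here means more inhibition of growth at the concentration tested, a lower number less inhibition of growth: compound 1 `N#Cc1ccc(-c2cnc3[nH]cc(-c4nnc(-c5ccc(F)cc5)o4)c(=O)c3c2)cc1` gives 18.9%, and compound 2 `CS(=O)(=O)c1ccc(-c2cnc3[nH]cc(-c4nnc(-c5ccncc5)o4)c(=O)c3c2)cc1` gives 7.83%, the lowest of the two, and the gap to compound 1 lies beyond the scatter. Compound 3 `CS(=O)(=O)c1ccc(-c2cnc3[nH]cc(-c4nnc(-c5ccc(F)cc5)o4)c(=O)c3c2)cc1` keeps the core of compound 2 but differs by 4-fluorophenyl in place of pyridin-4-yl on an aromatic carbon. Among the measured compounds shown here, no measured pair isolates this change, so its size is unknown; from compound 1 with 18.9%, which also carries the 4-fluorophenyl group, a small upward step is expected, not beyond the scatter. The step from compound 2 to compound 3 is therefore estimated at a number 6.2 percentage points higher from compound 2 to compound 3 (within the scatter). For compound 3 in this assay the expected value is 14%, within 4% to 27%.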

Compound 3, percent growth inhibition at one concentration: 18.7%
Estimate against measurement, compound 3: 4.7 percentage points below; low and high end bracket the measured number.
By their numbers in this assay, from the lowest: compound 2; then compounds 3 and 1 (each within the scatter of the next).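

At this aromatic carbon, the change to 4-fluorophenyl in place of pyridin-4-yl now has a measured size in this assay: a number 10.9 percentage points higher from compound 2 to compound 3 (beyond the scatter). With 4-fluorophenyl kept, methylsulfonyl in place of cyano gives a number 0.2 percentage points lower from compound 1 to compound 3 (within the scatter), so these two groups are not told apart here. Nothing available gives a cause for either step.

From the compounds shown here alone, it remains open whether an unsubstituted phenyl, an amine or a carboxylic acid at this carbon would match 4-fluorophenyl. Going by these compounds, it is also open whether the pyridin-4-yl step holds with cyano in place of methylsulfonyl.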